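Swapping the nitro end-group for a catechol on a stilbene amide

The source may hold more compounds than are shown below. What is called first, only, known or untested is meant among the compounds shown, and "the series" means these compounds.

Three compounds share one core and differ only in the group at the far end of the amide chain. Compound 1 `COc1cc(/C=C/c2ccc(NC(=O)/C=C/c3ccc(C(F)(F)F)cc3)cc2)cc(OC)c1` carries a 4-(trifluoromethyl)phenyl there, compound 2 `COc1cc(/C=C/c2ccc(NC(=O)/C=C/c3ccc([N+](=O)[O-])cc3)cc2)cc(OC)c1` a 4-nitrophenyl, and compound 3 `COc1cc(/C=C/c2ccc(NC(=O)/C=C/c3ccccn3)cc2)cc(OC)c1` a pyridin-2-yl. In a functional assay on MDA-MB-231 cells (Homo sapiens) for inhibition, read by MTT assay, with a stated time of 48 h (a lower number here means a stronger inhibitor, a higher number a weaker inhibitor), compound 1 gives 3520 nM. Compound 2 gives 11700 nM, the highest of the three numbers, so it is the weakest inhibitor of this set. Compound 3 gives 3400 nM. The step of a 3.3-fold higher number from compound 1 to compound 2 (0.52 log units; beyond the scatter) and the step of a 3.4-fold lower number from compound 2 to compound 3 (0.54 log units; beyond the scatter) both lie beyond the scatter, whereas a 1.0-fold lower number from compound 1 to compound 3 (0.02 log units; within the scatter) does not.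

Compound 4 `COc1cc(/C=C/c2ccc(NC(=O)/C=C/c3ccc(O)c(O)c3)cc2)cc(OC)c1` is not yet measured. Its change from compound 2 is 3,4-dihydroxyphenyl in place of 4-nitrophenyl on a double-bonded chain carbon bound to a double-bonded chain carbon. Both measured steps that replace the 4-nitrophenyl gave a lower number of roughly the same size, which suggests that removing that group is what matters, not what enters. A 3,4-dihydroxyphenyl differs from either replacement, so the two steps only point the way and do not fix the size. The expected step of a 2.9-fold lower number from compound 2 to compound 4 (0.47 log units; beyond the scatter) is therefore a modest fall. Compound 4 is estimated at 4000 nM in this assay, within a range from 1200 nM to 13000 nM.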

Compound 4, half-maximal inhibitory concentration: 4230 nM
For compound 4 the middle estimate is 1.1-fold (0.02 log units) below the measured one, and the stated range covers the measured number.
By their numbers in this assay, from the lowest: compounds 3, 1 and 4 (each within the scatter of the next); then compound 2.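

The 3,4-dihydroxyphenyl is a third replacement for the 4-nitrophenyl in this assay, and it also gives a lower number (a 2.8-fold lower number from compound 2 to compound 4 (0.44 log units; beyond the scatter)), so all three end-groups now measured against the 4-nitrophenyl shift the result the same way. This third end-group carries hydrogen-bond donors, which the 4-nitrophenyl does not have, yet it cannot be told apart from the other two replacements (a 1.2-fold higher number from compound 3 to compound 4 (0.09 log units; within the scatter); a 1.2-fold higher number from compound 1 to compound 4 (0.08 log units; within the scatter)). On a double-bonded chain carbon bound to a double-bonded chain carbon, this assay therefore separates only compound 2 from the others, while compound 1, compound 3 and compound 4 form a single group despite their quite different end-groups.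

Nothing among the data shown explains why compound 2 stands apart from the other three. Also open, from the compounds shown here alone, is whether this group of similar results would hold for end-groups of another kind, such as a plain unsubstituted phenyl, a phenyl bearing a carboxylic acid or an amine, or a single hydroxyl in place of the two on the 3,4-dihydroxyphenyl.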